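The source may hold more compounds than are shown below. What is called first, only, known or untested is meant among the compounds shown, and "the series" means these compounds.

Two compounds of this series carry a measured number in an assay on isolated protein (Oryctolagus cuniculus) with Thromboxane-A synthase (Homo sapiens) as the target, tested at 1 uM; on this read-out lower numbers stand for less inhibition and higher numbers for more inhibition at the one concentration tested (going by the name of the read-out). Compound 1, `CC(=O)OCCn1nc(-c2cccnc2)c2ccccc2c1=O`, gives 32% in this assay, and compound 2, `O=C(O)Cn1nc(-c2cccnc2)c2ccccc2c1=O`, gives 13%. Among the compounds with values here, the only step between measured compounds is a number 19 percentage points lower from compound 1 to compound 2 (beyond the scatter), which puts compound 2 at the lower of the two numbers, with compound 1 standing higher by an amount beyond the scatter.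

The unmeasured compound 3, `NCCn1nc(-c2cccnc2)c2ccccc2c1=O`, differs from compound 2 as follows: aminomethyl in place of carboxy on a saturated chain carbon bound to an aromatic nitrogen. Here a carboxy group leaves and an aminomethyl group enters, on a saturated chain carbon bound to an aromatic nitrogen. Within the data shown here, no measured step shows this exchange; the one step known, from an acetoxymethyl to a carboxy group at the same place, was of modest size. Because compound 2 sits at 13%, a move in either direction is possible, and a modest rise is estimated as a number 9 percentage points higher from compound 2 to compound 3 (within the scatter), with little firm ground under it. Compound 3 is therefore expected to give about 22% in this assay, estimated within a range from 5% to 45%.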

Compound 3, a percentage reported as inhibition, at one concentration (the size of the read-out at that concentration, not a potency): 29%
Beside the measured number, compound 3's estimate is 7 percentage points below it, within the range that was stated.
By their numbers in this assay, from the lowest: compound 2; then compounds 3 and 1 (each within the scatter of the next).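

In this assay, within the data shown here, a second group at this place, on a saturated chain carbon bound to an aromatic nitrogen, again moves the read-out: aminomethyl in place of carboxy gives a number 16 percentage points higher from compound 2 to compound 3 (beyond the scatter), so the carboxy group of compound 2 is not the only change here that produces a step beyond the scatter. Amino in place of acetoxy, on a saturated chain carbon two bonds along the chain from an aromatic nitrogen, gives a number 3 percentage points lower from compound 1 to compound 3 (within the scatter), which leaves those two end groups not told apart by this read-out and makes compound 2 the only one of the three standing apart from both others by more than the scatter. No measurement given here bears on what lies behind these steps.

The comparison of compound 2 with compound 3 changes the end group and the chain together, as carboxymethyl to 2-aminoethyl, so a carboxylic acid on a longer chain, such as carboxyethyl, would be needed to separate the two. As far as these compounds go, how a dimethylamine at the end of the 2-aminoethyl chain, or a simple alcohol there, would read in this assay also remains open.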